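Working notes: cytotoxicity tolerance across compounds 1 to 4

The compounds below may be only part of what the source reports. "The series", "measured", "known", "first", "only" and "open" are said of these compounds alone.

Compound 1 `CS(=O)(=O)CCCn1c(Cn2nc(S(C)(=O)=O)c3ccncc32)nc2cc(Cl)ccc21`: in an ADME assay on HEp-2 cells (Homo sapiens) for cytotoxicity, with a stated time of 4 days (a lower number here means that less compound is tolerated, a higher number that more compound is tolerated), compound 1 gives > 100000 nM, which is a limit of the assay and not a number.
Compound 2 `CCS(=O)(=O)c1cn(Cc2nc3cc(Cl)ccc3n2CCCS(C)(=O)=O)c2ccccc12`: in this assay compound 2 gives > 100000 nM, again a limit of the assay.
Compound 3 `CS(=O)(=O)CCCn1c(Cn2cc(S(=O)(=O)C3CC3)c3ccccc32)nc2cc(Cl)ccc21`: in this assay compound 3 gives > 100000 nM, also a limit of the assay.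

Compound 1 therefore stands where every measured member stands: at the limit of > 100000 nM in this assay, at which 3 of the 3 values shown sit. Among the measured compounds shown here, no compound is separated from another by a readable number. For the measured compounds named here, the single one-place step measured, a step that the two limits leave unreadable from compound 2 to compound 3, is unreadable for that reason and gives no size.

Compound 4 `CS(=O)(=O)c1nn(Cc2nc3cc(Cl)ccc3n2CC2COC2)c2cnccc12` differs from compound 1 by oxetan-3-yl in place of 2-(methylsulfonyl)ethyl on a saturated chain carbon bound to an aromatic nitrogen. Going by the values given here, no measured step touches this change; the only measured step concerns a sulfonyl substituent and is unreadable anyway. What can be said rests on the limit alone: all three measured compounds sit there, and nothing shown separates any of them.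

Compound 4 is therefore expected to sit at the same limit, because the limit of > 100000 nM in this assay, at which 3 of the 3 values shown sit, holds for every value shown, so the step that the limit leaves unreadable from compound 1 to compound 4 is expected to be none that the assay can read. The estimate for compound 4 is 120000 nM with a range from 40000 nM to 400000 nM, most likely reported only as a limit.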

Compound 4, half-maximal cytotoxic concentration: > 100000 nM
Compound 4: only a limit was reported; the forecaster's own chance of this, stated with the estimate: 80%; the middle value does not contradict the limit.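

In this assay compound 4 gives > 100000 nM, a limit of the assay and not a number. No step from compound 1 to compound 4 can be read, because both compounds stand at the same limit: the limit of > 100000 nM in this assay, at which 4 of the 4 values shown sit.

The compounds shown leave open where the half-maximal cytotoxic concentration of any of them lies, and whether oxetan-3-yl in place of 2-(methylsulfonyl)ethyl changes it.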